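A new group on the amide-type nitrogen of compound 2

The compounds below may be only part of what the source reports. "The series", "measured", "known", "first", "only" and "open" are said of these compounds alone.

Measured so far in a functional assay on IGROV-1 cells (Homo sapiens) for inhibition; a higher number here means a weaker inhibitor of growth, a lower number a stronger inhibitor of growth:
- compound 1 `C=C1C(=O)O[C@H]2[C@H]1CC/C(COC(=O)N1CCC(F)(F)CC1)=C\CC[C@@]1(C)O[C@@H]21`: 2310 nM
- compound 2 `C=C1C(=O)O[C@H]2[C@H]1CC/C(COC(=O)NCCN1CCCC1)=C\CC[C@@]1(C)O[C@@H]21`: 4090 nM

Only these two compounds have been measured, and their values lie within the usual scatter of each other. Compound 2 therefore cannot be separated from compound 1 on these numbers.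

The next compound, compound 3 `C=C1C(=O)O[C@H]2[C@H]1CC/C(COC(=O)Nc1n[nH]c(SC)n1)=C\CC[C@@]1(C)O[C@@H]21`, changes one group of compound 2: 5-(methylsulfanyl)-1H-1,2,4-triazol-3-yl in place of 2-(pyrrolidin-1-yl)ethyl on an amide-type nitrogen. In words, 5-(methylsulfanyl)-1H-1,2,4-triazol-3-yl takes the place of 2-(pyrrolidin-1-yl)ethyl on an amide-type nitrogen.

Going by the values given here, one measured step bears on this change. It replaces 4,4-difluoropiperidin-1-yl on a carbonyl carbon with (2-(pyrrolidin-1-yl)ethyl)amino, and the result is a 1.8-fold higher number from compound 1 to compound 2 (0.25 log units; within the scatter). Among the compounds with values here, that one small step is the only guide, and neither measured compound carries the incoming group, so the direction is uncertain and the range has to stay wide.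

No change beyond the scatter is expected, and the expected step is a 1.6-fold lower number from compound 2 to compound 3 (0.21 log units; within the scatter). In this assay the estimate for compound 3 is 2500 nM, with an expected range from 700 nM to 7000 nM.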

Compound 3, concentration for 50% growth inhibition: 3660 nM
For compound 3 the middle estimate is 1.5-fold (0.17 log units) below the measured one, and the stated range covers the measured number.
By their numbers in this assay, from the lowest: compounds 1, 3 and 2 (each within the scatter of the next).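

In this assay, 5-(methylsulfanyl)-1H-1,2,4-triazol-3-yl in place of 2-(pyrrolidin-1-yl)ethyl on the amide-type nitrogen gives a 1.1-fold lower number from compound 2 to compound 3 (0.05 log units; within the scatter), so these two groups cannot be told apart here, even though one is a five-membered non-aromatic ring with 1 hetero atom on a chain and the other a five-membered aromatic ring with 3 hetero atoms. The comparison with the 4,4-difluoropiperidin-1-yl carbonyl compound gives a 1.6-fold higher number from compound 1 to compound 3 (0.20 log units; within the scatter), so this third, quite different group on the carbonyl carbon also stays within the scatter, and so far no group at this place separates from another. Nothing available explains why such different groups give values that cannot be separated.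

Going by these compounds, it remains open whether any group on this amide-type nitrogen can move the number beyond the scatter at all, in either direction. A small methyl, a plain phenyl ring or a chain ending in a carboxylic acid would probe that question, as none of these groups appears among the three compounds shown.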